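The compounds below may be only part of what the source reports. "The series", "measured", "known", "first", "only" and "open" are said of these compounds alone.

In an ADME assay on HCT-116 cells (Homo sapiens) for cytotoxicity, read by CellTiter-Glo, with a stated time of 72 h (a lower number here means a stronger inhibitor, a higher number a weaker inhibitor), none of the three tested compounds gives a number. Compound 1 `CC1CCN(C2CCN(S(=O)(=O)c3cnc(Cl)s3)CC2)CC1` reads > 10000 nM, which is a limit. Compound 2 `CC1CCN(C2CCN(S(=O)(=O)c3cncc(Br)c3)CC2)CC1` reads > 10000 nM, which is also a limit. From the compounds shown here alone, compound 3 `CC1CCN(C2CCN(S(=O)(=O)c3ccc(F)cc3F)CC2)CC1` reads > 5000 nM, again a limit, so its true place on the scale is unknown. Compound 4 `CC1CCN(C2CCN(S(=O)(=O)c3cc(Cl)cc(Cl)c3)CC2)CC1` differs from it in one place: 3,5-dichlorophenyl in place of 2,4-difluorophenyl on a sulfonyl sulfur. For the measured compounds named here, the steps that bear on this change are swaps at the same sulfonyl sulfur: a step that the two limits leave unreadable from compound 1 to compound 2, a step that the two limits leave unreadable from compound 1 to compound 3 and a step that the two limits leave unreadable from compound 2 to compound 3. None of them has a readable size, so no clear direction can be drawn from them, and no shift beyond the scatter is expected in this assay. The expected step is a step that the limit leaves unreadable from compound 3 to compound 4. Compound 4 is estimated at 10000 nM, with an expected range from 4000 nM to 25000 nM.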

Compound 4, half-maximal inhibitory concentration: > 5000 nM
Compound 4 ended at the assay's limit (the forecaster's own chance of this, stated with the estimate: 80%); the middle value is on the limit's open side.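

Compound 4 gives > 5000 nM, which is a limit. Its steps from compound 1, compound 2 and compound 3 cannot be read. The compounds shown leave open where any of the four truly stands in this assay.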